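The compounds below may be only part of what the source reports. "The series", "measured", "known", "first", "only" and "open" are said of these compounds alone.

Of the compounds shown here, three sharing one core have been tested in a functional assay on MDA-MB-231 cells (Homo sapiens) for antiproliferative activity, read by MTT assay, with a stated time of 72 h; on this read-out lower numbers stand for stronger inhibition and higher numbers for weaker inhibition. Compound 1 `O=C(Nc1cccc(C(=O)O/N=C2\CCCc3noc(-c4cccc(F)c4)c32)c1)c1cccc(F)c1` gives 9300 nM in this assay. Compound 2 `CC1(C)C/C(=N\OC(=O)c2cccc(NC(=O)c3cccc(F)c3)c2)c2c(-c3cccc(F)c3)noc2C1` reaches only the limit of this assay, > 25000 nM, a limit and not a measured number. Compound 3 `CC1(C)C/C(=N\OC(=O)c2cccc(NC(=O)c3cccc(F)c3)c2)c2c(noc2-c2cccc(F)c2)C1` likewise stops at the limit of this assay, > 25000 nM, again a limit rather than a number. Among the three values shown, compound 3 thus stands at the weak end together with compound 2, while compound 1 alone yields a number; the limit of > 25000 nM in this assay, at which 2 of the 3 values shown sit, marks where these two sit. No pair of these compounds differs in only one place, so no single step between measured compounds is available.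

Compound 4 `COc1ccc(-c2onc3c2/C(=N/OC(=O)c2cccc(NC(=O)c4cccc(F)c4)c2)CC(C)(C)C3)cc1OC` has not yet been measured in this assay. It differs from compound 3 in one place: 3,4-dimethoxyphenyl in place of 3-fluorophenyl on an aromatic carbon. Within the data shown here, because compound 3 rests at a limit > 25000 nM, no measured step shows how such an exchange acts, and the step of an at least 1.2-fold lower number from compound 3 to compound 4 (0.09 log units; that floor lies within the scatter) is estimated as a modest one, possibly toward a measurable number. Compound 4 is therefore expected to give about 20000 nM in this assay, with a range from 5000 nM to 60000 nM.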

Compound 4, half-maximal inhibitory concentration: > 25000 nM
Compound 4 gave a limit, no number (the forecaster's own chance of this, stated with the estimate: 50%); at least 1.2-fold (0.09 log units) between middle value and limit.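

In this assay compound 4 stops at the limit > 25000 nM and gives no number. Compound 3 also rests at a limit, so no step can be read between compound 3 and compound 4: the limit of > 25000 nM in this assay, at which 3 of the 4 values shown sit. The compounds shown leave open whether 3,4-dimethoxyphenyl in place of 3-fluorophenyl changes the activity at all.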